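Halogen swap on the aryl urea of compound 3

This account rests on a few compounds, and the source may have more. Where it says the series, first, only, none or still open, it means among the compounds named here.

Measured compounds:
compound 1, `COc1cc(NC(C)CCCNC(=O)NNC(=O)Nc2cccc(F)c2)c2ncccc2c1`, 150 nM in a functional assay on MCF7 cells (Homo sapiens) for inhibition, read by MTT assay, with a stated time of 72 h; a higher number here means a weaker inhibitor, a lower number a stronger inhibitor
compound 2, `COc1cc(NC(C)CCCNC(=O)NNC(=O)Nc2cccc(Cl)c2)c2ncccc2c1`, 220 nM in this assay
compound 3, `COc1cc(NC(C)CCCNC(=O)Nc2cccc(F)c2)c2ncccc2c1`, 18000 nM in this assay

Compound 3 has the highest number of the three in this assay, and its gap to both others is beyond the scatter: a 120-fold higher number from compound 1 to compound 3 (2.08 log units; beyond the scatter) and an 82-fold higher number from compound 2 to compound 3 (1.91 log units; beyond the scatter). It is thus the weakest of the measured set, and it is the one that lacks the carbamoylamino linker present in compounds 1 and 2.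

Compound 4, `COc1cc(NC(C)CCCNC(=O)Nc2ccc(Br)cc2)c2ncccc2c1`, is not yet measured. It differs from compound 3 in one place: 4-bromophenyl in place of 3-fluorophenyl on an amide-type nitrogen.

Going by the values given here, only one measured step bears on this change, and only loosely. In compounds 1 and 2 the same aryl carries either fluoro or chloro, and that swap gave a 1.5-fold higher number from compound 1 to compound 2 (0.17 log units; within the scatter). Among the compounds with values here, no measured pair shows bromo, and none shows a halogen moved to a different place on the ring, so those parts of the change are untested here.

Given that the one comparable halogen swap stayed within the scatter, the step of no change at the digits printed from compound 3 to compound 4 (within the scatter) is expected to be small, with no clear direction. Compound 4 is therefore estimated at 18000 nM in this assay, with a range of 6000 nM to 50000 nM.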

Compound 4, half-maximal inhibitory concentration: 2600 nM
Compound 4: middle estimate off by 6.9-fold (0.84 log units), on the high side, and the stated range ends above it.
By their numbers in this assay, from the lowest: compounds 1 and 2 (each within the scatter of the next); then compound 4; then compound 3.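

Placing 4-bromophenyl in place of 3-fluorophenyl on the amide-type nitrogen in this assay gave a 6.9-fold lower number from compound 3 to compound 4 (0.84 log units; beyond the scatter), so the aryl group at this position can shift the result beyond the scatter, which the fluoro-to-chloro swap between compound 1 and compound 2 had not shown. The shift still leaves compound 4 apart from the two compounds carrying the carbamoylamino linker, with a 12-fold higher number from compound 2 to compound 4 (1.07 log units; beyond the scatter) and a 17-fold higher number from compound 1 to compound 4 (1.24 log units; beyond the scatter), so the 4-bromophenyl urea does not reach their range. No supporting measurement bears on this step, and the data offer no explanation for it.

The change altered both the halogen and its place on the ring, so the compounds shown cannot say which of the two carries the step, nor whether 4-bromophenyl would act the same way on the carbamoylamino linker of compound 1 and compound 2. From the compounds shown here alone, how a plain phenyl, or a ring bearing a methoxy group, a nitrile or a carboxylic acid, would compare on this nitrogen also remains open.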